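Swapping the Ring-Nitrogen Substituent: From Fluorophenyl to Nitrophenyl

This account rests on a few compounds, and the source may have more. Where it says the series, first, only, none or still open, it means among the compounds named here.

Measured compounds, each in a functional assay on HEK293 cells for agonist activity at Free fatty acid receptor 1 (Homo sapiens), read by fluorescence and calcium flux; on this read-out lower numbers stand for an effect already at smaller amounts and higher numbers for an effect only at larger amounts of compound:
- Compound 1, `CC#CC(CC(=O)O)c1ccc(OCc2ccc(C(=O)N3CCN(C4CCCCC4)CC3)s2)cc1`, gives 820 nM.
- Compound 2, `CC#CC(CC(=O)O)c1ccc(OCc2ccc(C(=O)N3CCN(c4ccncc4)CC3)s2)cc1`, reaches only a limit, > 5000 nM.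
- Compound 3, `CC#CC(CC(=O)O)c1ccc(OCc2ccc(C(=O)N3CCN(c4ccccc4F)CC3)s2)cc1`, gives 113 nM.

All three share one core and differ only in the group on the amine nitrogen of the ring. Compound 3 has the lowest number of the two real values: it sits a 7.3-fold lower number from compound 1 to compound 3 (0.86 log units; beyond the scatter). For compound 2 the number is a limit, not a measurement; this is the limit of > 5000 nM in this assay, at which 1 of the 3 values shown sits. Against that limit, the move an at least 44-fold lower number from compound 2 to compound 3 (1.64 log units; beyond the scatter) is large, and the move an at least 6.0-fold higher number from compound 1 to compound 2 (0.78 log units; beyond the scatter) is at least modest.

Compound 4, `CC#CC(CC(=O)O)c1ccc(OCc2ccc(C(=O)N3CCN(c4cccc([N+](=O)[O-])c4)CC3)s2)cc1`, has not been measured. It differs from compound 3 by 3-nitrophenyl in place of 2-fluorophenyl on an amine nitrogen in a ring. Both steps that bear on it replace a group on the same ring nitrogen. The fluorophenyl of compound 3 gave the best number, while the pyridinyl of compound 2, a ring with a nitrogen in it, fell off to the limit. The nitrophenyl of compound 4 keeps the all-carbon ring but brings two hydrogen-bond acceptors, so a step in this assay somewhat back toward weaker activity is expected, about a 2.7-fold higher number from compound 3 to compound 4 (0.42 log units; beyond the scatter). Compound 4 is therefore estimated at 300 nM, within 80 nM to 1500 nM.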

Compound 4, half-maximal effective concentration: 187 nM
The estimate for compound 4 lay 1.6-fold (0.21 log units) above the measured number; the range from low to high includes it.
By their numbers in this assay, from the lowest: compounds 3 and 4 (each within the scatter of the next); then compound 1. At a limit, above all of these: compound 2.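

In this assay, a 1.7-fold higher number from compound 3 to compound 4 (0.22 log units; within the scatter), so on this ring nitrogen the 3-nitrophenyl group, which carries 2 hydrogen-bond acceptors, cannot be told apart from 2-fluorophenyl, which has none. Among these compounds, the earlier compounds offered only one ring of carbon alone at this position, and now a second one, with a quite different group on it, also clears cyclohexyl, a 4.4-fold lower number from compound 1 to compound 4 (0.64 log units; beyond the scatter). The pyridin-4-yl group gives a limit and not a number, so an at least 26-fold lower number from compound 2 to compound 4 (1.42 log units; beyond the scatter) marks only a bound on the gap between these two rings: the limit of > 5000 nM in this assay, at which 1 of the 4 values shown sits.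

The compounds shown leave open how much of the activity comes from the aromatic ring itself and how much from what it carries, since a plain phenyl group, with neither fluorine nor nitro, is not among them. They also leave open whether a nitrile or an amine in place of the nitro group would keep the number in this range, and 2-fluorophenyl and 3-nitrophenyl differ in both the group and its place on the ring, so those two effects cannot be separated here.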